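The source may hold more compounds than are shown below. What is called first, only, known or untested is meant among the compounds shown, and "the series" means these compounds.

Measured so far in an assay on NIH3T3 cells for binding affinity to melatonin receptor type 1B (Homo sapiens); on this read-out higher numbers stand for weaker inhibition and lower numbers for stronger inhibition: compound 1 `CC(=O)NCCCc1cccc2oc(CCCCc3ccccc3)cc12` gives 127 nM; compound 2 `CCCC(=O)NCCCc1cccc2oc(CCCCc3ccccc3)cc12` gives 82 nM.

Compound 2 holds the lower of the two numbers, but the step of a 1.5-fold lower number from compound 1 to compound 2 (0.19 log units; within the scatter) stays within the scatter, so no order between them is claimed. Compound 3 `CC(C)C(=O)NCCCc1cccc2oc(CCCCc3ccccc3)cc12` differs from compound 2 by isopropyl in place of propyl on a carbonyl carbon. Among the compounds with values here, only one measured step is available, and it concerns chain length rather than branching, so it bears little on this change. Without a branched analogue measured, a step near zero is expected: a 1.2-fold higher number from compound 2 to compound 3 (0.09 log units; within the scatter). The estimate for compound 3 is 100 nM, ranging from 40 nM to 250 nM.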

Compound 3, inhibition constant: 83 nM
Estimate against measurement, compound 3: 1.2-fold (0.08 log units) above; the measured number falls inside the stated range.
By their numbers in this assay, from the lowest: compounds 2, 3 and 1 (each within the scatter of the next).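

In this assay, branching at this carbonyl carbon gives a 1.0-fold higher number from compound 2 to compound 3 (0.01 log units; within the scatter) and so does not separate isopropyl from propyl. Isopropyl in place of methyl gives a 1.5-fold lower number from compound 1 to compound 3 (0.18 log units; within the scatter) as well, so methyl, propyl and isopropyl on this carbon remain unresolved from one another, now for a branched group as well as a straight chain. Nothing available accounts for these close numbers.

Going by these compounds, whether tert-butyl, cyclohexyl or a longer chain on this carbonyl carbon would give a step beyond the scatter stays open. Also open, on these data alone, is whether an amine there would do so.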